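The source may report more compounds than this note shows. Statements on the series, on what has been measured and on what is new or still open speak of the compounds shown alone.

Measured in a toxicity assay on THP-1 cells (Homo sapiens) for inhibition; on this read-out higher numbers stand for lower toxicity in this test and lower numbers for higher toxicity in this test:
Compound 1 `Cc1ccc(-c2cnc(NC(=O)c3ccc(F)cc3)n2C)cc1`: 60000 nM
Compound 2 `Cn1c(-c2ccc(C#N)cc2)cnc1NC(=O)c1ccc(F)cc1`: > 50000 nM (a limit)
Compound 3 `Cn1c(-c2ccc(F)cc2)cnc1NC(=O)c1ccc(F)cc1`: > 100000 nM (a limit)

Compound 3 has no exact number, and its entry of > 100000 nM is a limit of the assay. The same is true of compound 2, so only compound 1 has a measured value in this small set.

The next compound, compound 4 `Cn1c(-c2ccc([N+](=O)[O-])cc2)cnc1NC(=O)c1ccc(F)cc1`, carries nitro in place of fluoro on an aromatic carbon, para to a large group: nitro in place of fluoro on an aromatic carbon.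

Three measured steps changed this same aromatic position. The only one with a readable size is an at least 1.6-fold higher number from compound 1 to compound 3 (0.22 log units; that floor lies within the scatter), and its floor lies within the scatter. The other two are a step that the limit leaves unreadable from compound 1 to compound 2 and a step that the two limits leave unreadable from compound 2 to compound 3, and neither gives a size. These steps therefore offer no sign of a large change, though they cannot rule one out. No step beyond the scatter is expected in this assay, and the nearest exact anchor is compound 1 at 60000 nM. The expected change is an at least 1.6-fold lower number from compound 3 to compound 4 (0.22 log units; that floor lies within the scatter). A limit is also a likely report for this compound. For compound 4 the estimated value is 60000 nM, with an expected range from 20000 nM to 120000 nM.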

Compound 4, half-maximal cytotoxic concentration: > 50000 nM
Compound 4: no number, only a limit (the forecaster's own chance of this, stated with the estimate: 60%); the middle value is on the limit's open side.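

Among these compounds, compound 4 gives only a limit in this assay, > 50000 nM, so no step from compound 1, compound 2 or compound 3 to compound 4 can be read. The compounds shown leave open how far compound 2, compound 3 and compound 4 differ from one another, and how far each differs from compound 1.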